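The source may hold more compounds than are shown below. What is called first, only, known or untested is meant among the compounds shown, and "the series" means these compounds.

Measured compounds:
Compound 2 `Oc1ccc(-c2cc(-c3ccccc3)nc(-c3ccccc3Cl)c2)cc1` – 4990 nM
Compound 3 `Oc1ccc(-c2cc(-c3ccsc3)nc(-c3ccccc3Cl)c2)cc1` – 5830 nM
Compound 1 `Oc1ccc(-c2cc(-c3cccnc3)nc(-c3ccccc3Cl)c2)cc1` – "not determined" (no result reported)

In a functional assay on HCT-15 cells (Homo sapiens) for cytotoxicity, read by CCK-8 assay and cell counting, with a stated time of 2 days (a higher number here means a weaker inhibitor, a lower number a stronger inhibitor), compound 2 gives 4990 nM, the lower of the two numbers available, and compound 3 gives 5830 nM. Among the measured compounds shown here, the single step connecting them, a 1.2-fold higher number from compound 2 to compound 3 (0.07 log units; within the scatter), involves a thiophen-3-yl in place of phenyl on an aromatic carbon and lies within the scatter, so the two cannot be ordered. Compound 1 carries a pyridin-3-yl at that same position, but no result was reported for it.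

Compound 4 `Oc1ccc(-c2cc(-c3ccccc3)nc(-c3ccc(Cl)cc3)c2)cc1` is not yet measured. It differs from compound 2 by 4-chlorophenyl in place of 2-chlorophenyl on an aromatic carbon. For the measured compounds named here, no measured step touches the chlorophenyl group, so nothing directly bears on this change; the one step on record, a 1.2-fold higher number from compound 2 to compound 3 (0.07 log units; within the scatter), concerns a different group and shows that a modest aromatic variation elsewhere left the number essentially unmoved. On this thin basis the step of a 1.1-fold higher number from compound 2 to compound 4 (0.04 log units; within the scatter) is expected to stay within the scatter, in no firm direction. Compound 4 is therefore estimated at 5500 nM, with a range from 2000 nM to 15000 nM.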

Compound 4, half-maximal inhibitory concentration: 6920 nM
Beside the measured number, compound 4's estimate is 1.3-fold (0.10 log units) below it, within the range that was stated.
By their numbers in this assay, from the lowest: compounds 2, 3 and 4 (each within the scatter of the next).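

In this assay, the chlorophenyl group next to the ring nitrogen now has a measured step of its own: a 1.4-fold higher number from compound 2 to compound 4 (0.14 log units; within the scatter). Moving the chlorine from the 2-chlorophenyl to the 4-chlorophenyl arrangement therefore gives no change that can be told from the scatter, and compound 2 and compound 4 cannot be ordered. This position thus joins the phenyl position, where the step to thiophen-3-yl was also within the scatter, so neither change shown separates its pair of compounds. Nothing available explains this result or links it to any property of the two groups.

The compounds shown leave open whether any replacement at this position would move the number beyond the scatter. As far as these compounds go, an amine or a carboxylic acid in place of the chlorine, for example, remains untested among them, as does a change to the 4-hydroxyphenyl group.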